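This account rests on a few compounds, and the source may have more. Where it says the series, first, only, none or still open, it means among the compounds named here.

For the measured compounds named here, compound 1 `Cc1cccc(CCCCCCC(=O)N2CCCC2)c1` is the one compound in this set for which a number exists: in an assay on HEK293 cells for inhibition of N-acylethanolamine-hydrolyzing acid amidase (Rattus norvegicus), read by LC-MS, with a stated time of 30 min (a higher number here means a weaker inhibitor, a lower number a stronger inhibitor), compound 1 gives 8300 nM. Compound 2 `O=C(CCCCCCc1ccccc1Cl)N1CCCC1` carries its chloro on the ring in a different position, and in this assay compound 2 gives only > 100000 nM. For compound 2 that reading is a limit of the assay, not a number. Of the two values shown, one thus sits at a limit: the limit of > 100000 nM in this assay, at which 1 of the 2 values shown sits.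

Compound 3 `O=C(CCCCCCc1cccc(Cl)c1)N1CCCC1` differs from compound 1 at a single site: chloro in place of methyl on an aromatic carbon. Going by the values given here, no measured pair in this set isolates that exchange, so the size of the step has to be judged without a direct precedent. The expected step in this assay, a 1.2-fold higher number from compound 1 to compound 3 (0.08 log units; within the scatter), is small, in either direction, and not clearly beyond the usual scatter of the measurement. Compound 3 is therefore estimated at 10000 nM, with a plausible range from 3000 nM to 40000 nM in this assay.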

Compound 3, half-maximal inhibitory concentration: 3700 nM
Beside the measured number, compound 3's estimate is 2.7-fold (0.43 log units) above it; the measured number falls inside the stated range.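

Chloro in place of methyl on an aromatic carbon, meta to a large group, gives a 2.2-fold lower number from compound 1 to compound 3 (0.35 log units; beyond the scatter) in this assay, a modest change, but the first measured step in this set, and it shows that this position takes chloro with no loss of inhibition. Compound 2, which carries its chloro at a different place on the ring, reads > 100000 nM, and that reading is a limit of the assay and not a number. Among these chloro compounds, then, the presence of chloro does not by itself settle the reading, and its place on the ring matters, though this rests on compound 3 and compound 2 alone.

Going by these compounds, whether methoxy, trifluoromethyl or an amine at this same position would match chloro, and whether the step would hold on a longer chain, stays open. The compounds shown also offer nothing that explains the step itself.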